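Replacing the Diethylcarbamoyl Group with Methyl on Compound 3

The source may report more compounds than this note shows. Statements on the series, on what has been measured and on what is new or still open speak of the compounds shown alone.

Compound 1, `CN1CCC[C@H]1COc1cccnc1`, in an assay on membranes from brain for displacement of a labelled ligand from Neuronal acetylcholine receptor; alpha4/beta2 (Rattus norvegicus); a higher number here means a weaker inhibitor, a lower number a stronger inhibitor: 0.15 nM
Compound 2, `CN1CCC[C@H]1COc1cccnc1Br`, in this assay: 451 nM
Compound 3, `CCN(CC)C(=O)c1ccncc1OC[C@@H]1CCCN1C`, in this assay: 2830 nM

Compound 3 stands highest of the three numbers, with compound 2 its nearest neighbour and compound 1 furthest away. Compound 4, `Cc1ccncc1OC[C@@H]1CCCN1C`, differs from compound 3 by methyl in place of diethylcarbamoyl on an aromatic carbon. For the measured compounds named here, two measured steps bear on this change: a 3000-fold higher number from compound 1 to compound 2 (3.48 log units; beyond the scatter) and a 19000-fold higher number from compound 1 to compound 3 (4.28 log units; beyond the scatter), both large and in the same direction, so any group at this carbon has so far raised the number considerably. Because a 3000-fold higher number from compound 1 to compound 2 (3.48 log units; beyond the scatter) is smaller than a 19000-fold higher number from compound 1 to compound 3 (4.28 log units; beyond the scatter), a modest return toward compound 2 is expected, and compound 4 is expected to show an 8.1-fold lower number from compound 3 to compound 4 (0.91 log units; beyond the scatter) in this assay. In this assay compound 4 is estimated at 350 nM, with a range from 60 nM to 1800 nM.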

Compound 4, inhibition constant: 4.12 nM
Compound 4: middle estimate off by 85-fold (1.93 log units), on the high side; the measured number lies below the stated range.
By their numbers in this assay, from the lowest: compound 1; then compound 4; then compound 2; then compound 3.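

In this assay, the step of a 690-fold lower number from compound 3 to compound 4 (2.84 log units; beyond the scatter) shows that most of the loss seen with diethylcarbamoyl is not a cost of carrying just any group at this carbon. Even methyl is not neutral here, however: the step of a 27-fold higher number from compound 1 to compound 4 (1.44 log units; beyond the scatter) still leaves compound 4 well short of compound 1, which has hydrogen at this carbon. Nothing measured here accounts for the size of either step. As far as these compounds go, whether an ethyl chain, a methoxy group or a primary amide at this carbon would fall closer to compound 4 or to compound 3 remains open.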